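Returning the Methyl to the Amide Nitrogen

The compounds below may be only part of what the source reports. "The series", "measured", "known", "first", "only" and "open" are said of these compounds alone.

Compound 3 `COCc1cccc(CNC(=O)c2nn(-c3ccc(F)cc3)c(OC[C@@H](O)C[C@@H](O)CC(=O)O)c2C(C)C)c1` holds the second highest of three numbers in an assay on microsomes from liver for inhibition of 3-hydroxy-3-methylglutaryl-coenzyme A reductase (Rattus norvegicus); on this read-out lower numbers stand for stronger inhibition and higher numbers for weaker inhibition: compound 3 gives 31 nM. Its nearest neighbour is compound 2 `CC(C)c1c(C(=O)N2CCCCC2)nn(-c2ccc(F)cc2)c1OC[C@@H](O)C[C@@H](O)CC(=O)O`, which gives 47 nM; the two are within the scatter, as a 1.5-fold lower number from compound 2 to compound 3 (0.18 log units; within the scatter) shows. Furthest away is compound 1 `CC(C)c1c(C(=O)N(C)Cc2ccccc2)nn(-c2ccc(F)cc2)c1OC[C@@H](O)C[C@@H](O)CC(=O)O`, which gives 5.2 nM, and the step of a 6.0-fold higher number from compound 1 to compound 3 (0.78 log units; beyond the scatter) lies beyond the scatter. Compound 4 `CC(C)c1c(C(=O)N(C)[C@H](C)c2ccccc2)nn(-c2ccc(F)cc2)c1OC[C@@H](O)C[C@@H](O)CC(=O)O` differs from compound 3 in a single place: methyl(1-phenylethyl)amino in place of (3-(methoxymethyl)benzyl)amino on a carbonyl carbon.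

Among the compounds with values here, two measured steps bear on this. Going from compound 1 to compound 3 swapped benzyl(methyl)amino for (3-(methoxymethyl)benzyl)amino and produced a 6.0-fold higher number from compound 1 to compound 3 (0.78 log units; beyond the scatter). Going from compound 1 to compound 2 swapped benzyl(methyl)amino for piperidin-1-yl and produced a 9.0-fold higher number from compound 1 to compound 2 (0.96 log units; beyond the scatter). Both steps away from compound 1 weakened inhibition by a modest amount. Compound 4 carries methyl(1-phenylethyl)amino, which, like compound 1, has a methyl on the amide nitrogen and a plain benzene ring, and which adds one defined stereocentre. The expectation is therefore a step back toward compound 1 rather than a further weakening, estimated at a 3.1-fold lower number from compound 3 to compound 4 (0.49 log units; beyond the scatter). Compound 4 is expected to give about 10 nM in this assay, with a likely range from 3 nM to 40 nM.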

Compound 4, half-maximal inhibitory concentration: 21 nM
The estimate for compound 4 lay 2.1-fold (0.32 log units) below the measured number, and the stated range covers the measured number.
By their numbers in this assay, from the lowest: compound 1; then compounds 4, 3 and 2 (each within the scatter of the next, the first and the last beyond it).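

Placing a methyl on the saturated chain carbon bound to an amide-type nitrogen and an aromatic carbon is the only change that separates compound 1 from compound 4, and in this assay it gives a modest loss of inhibition (a 4.0-fold higher number from compound 1 to compound 4 (0.61 log units; beyond the scatter)), so keeping the methyl on the amide nitrogen and the plain benzene ring does not preserve the number of compound 1. Compound 4 is also separated from compound 2, which carries piperidin-1-yl on the carbonyl carbon (a 2.2-fold lower number from compound 2 to compound 4 (0.35 log units; beyond the scatter)), but not from compound 3, which has the amide hydrogen and a methoxymethyl group (a 1.5-fold lower number from compound 3 to compound 4 (0.17 log units; within the scatter)), so two quite different amide groups cannot be told apart here. No supporting data are available to explain any of these steps.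

The compounds shown leave open whether the opposite stereocentre on that chain carbon would give a different number from the one form of methyl(1-phenylethyl)amino seen here. They also leave open whether an ethyl on that carbon, or a methoxymethyl on the benzene ring of compound 1, would move the number further.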